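Removing a Methoxy Group from a Fluorinated Analogue

The compounds below may be only part of what the source reports. "The series", "measured", "known", "first", "only" and "open" are said of these compounds alone.

compound 1, `COc1cc(-c2cccc3nc(-c4ccccc4)oc23)cc(OC)c1OC`: > 25000 nM, a limit of the assay
compound 2, `COc1ccc(-c2nc3cccc(-c4cc(OC)c(OC)c(OC)c4)c3o2)cc1`: > 25000 nM, a limit of the assay
compound 3, `COc1ccc(-c2nc3cccc(-c4cc(OC)c(OC)c(OC)c4)c3o2)cc1F`: > 25000 nM, a limit of the assay

The three measured compounds share one core and differ only in what sits on a single aromatic carbon. In a functional assay on MCF7 cells (Homo sapiens) for antiproliferative activity, read by MTT assay, with a stated time of 48 h (on this read-out lower numbers stand for stronger inhibition and higher numbers for weaker inhibition), compound 2 gives only a limit, > 25000 nM. Compound 1 likewise gives only a limit, > 25000 nM. Compound 3 too gives only a limit, > 25000 nM. All three values sit at the limit of > 25000 nM in this assay, at which 3 of the 3 values shown sit, so none of the steps between them can be read: a step that the two limits leave unreadable from compound 2 to compound 1, a step that the two limits leave unreadable from compound 2 to compound 3 and a step that the two limits leave unreadable from compound 1 to compound 3 are each unreadable in size.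

The change from compound 2 to compound 1 is hydrogen in place of methoxy on an aromatic carbon. Compound 4, `COc1cc(-c2cccc3nc(-c4cccc(F)c4)oc23)cc(OC)c1OC`, has not yet been measured in this assay. It differs from compound 3 by hydrogen in place of methoxy on an aromatic carbon, the same kind of change, though here the place is ortho to a fluoro group, which it is not in the change from compound 2 to compound 1. The cores of compound 3 and compound 2 themselves differ by fluoro in place of hydrogen on an aromatic carbon.

Because compound 3 sits at the limit of > 25000 nM in this assay, at which 3 of the 3 values shown sit, and because the earlier step of this kind a step that the two limits leave unreadable from compound 2 to compound 1 left both ends at that same limit, the expectation for compound 4 is modest. Compound 4 is expected to show the step that the limit leaves unreadable from compound 3 to compound 4. Compound 4 is thus estimated at 30000 nM in this assay, plausibly between 10000 nM and 100000 nM, and most likely reported only as a limit.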

Compound 4, half-maximal inhibitory concentration: > 25000 nM
Compound 4: a limit, no number; the forecaster's own chance of this, stated with the estimate: 85%; the middle value does not contradict the limit.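

In this assay compound 4 gives > 25000 nM, a limit of the assay and not a number. No step from compound 1, compound 2 or compound 3 to compound 4 can be read, as all four compounds stand at the same limit: the limit of > 25000 nM in this assay, at which 4 of the 4 values shown sit.

The compounds shown leave open whether hydrogen in place of methoxy, or fluoro in place of hydrogen, makes any difference to this read-out on the shared core.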